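An isomer step in an oral analgesic series

This account rests on a few compounds, and the source may have more. Where it says the series, first, only, none or still open, it means among the compounds named here.

Measured in a functional assay on the whole organism (Tail, strain ICR) with Mus musculus as the target, in the tail flick test, with a stated time of 120 min, at a dose of 25 umol/kg by the oral route; on this read-out higher numbers stand for a stronger effect at the one dose given and lower numbers for a weaker effect:
- compound 1, `CC[C@H](C)[C@H](NC(=O)CN(c1ncnc2c1ncn2C1CCCCO1)C1CC1)C(=O)OCc1ccccc1`: 20.4%
- compound 2, `NC(=O)C[C@H](NC(=O)CN(c1nc(Cl)nc2[nH]cnc12)C1CC1)C(=O)O`: 17%

Compound 1 holds the higher of the two numbers, though compound 2 sits within the scatter of it, so the two cannot be told apart. Compound 3 `CC(C)C[C@H](NC(=O)CN(c1ncnc2c1ncn2C1CCCCO1)C1CC1)C(=O)OCc1ccccc1` is not yet measured. It differs from compound 1 by isobutyl in place of sec-butyl on a saturated chain carbon bound to an amide-type nitrogen and a carbonyl carbon; the two are built from the same atoms joined differently. Going by the values given here, no step between measured compounds shows what such a change does. Compound 3 is therefore expected to stay near the value of compound 1, 20.4%, with a step of a number 0.4 percentage points lower from compound 1 to compound 3 (within the scatter) expected not to go beyond the scatter in either direction. The estimate for compound 3 in this assay is 20%, within 8% to 34%.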

Compound 3, a percentage reported as activity, at one dose (the size of the read-out at that dose, not a potency): 12.8%
Compound 3: the middle estimate sits 7.2 percentage points above what was measured; low and high end bracket the measured number.
By their numbers in this assay, from the lowest: compounds 3, 2 and 1 (each within the scatter of the next).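

Isobutyl in place of sec-butyl on a saturated chain carbon bound to an amide-type nitrogen and a carbonyl carbon gives the first step that can be read at this position: in this assay it is a number 7.6 percentage points lower from compound 1 to compound 3 (within the scatter). Joining the same carbon atoms differently, and so losing the defined stereocentre of the sec-butyl group, therefore does not separate the two compounds at this one dose. Nothing at hand explains the size of this step. Going by these compounds, whether a longer chain, an amine or a carboxylic acid at this place would move the read-out beyond the scatter remains open.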